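A few compounds are considered here, and "the series" means these few. Any claim that something is new, unique, unknown or untested is made for them only; others in the source may bear on it.

Compound 1 `Nc1sc(-c2ccc(Cl)cc2)c(-c2ccc(Cl)cc2)c1C(=O)N1CCCCC1` gives 14300 nM in a functional assay on PC-3 cells (Homo sapiens) for inhibition, read by sulforhodamine B assay, with a stated time of 72 h (a lower number here means a stronger inhibitor, a higher number a weaker inhibitor), the lower of the two numbers seen so far, although the gap to its neighbour lies within the scatter. Among the compounds with values here, compound 2 `Nc1sc(-c2ccc(Cl)cc2)c(-c2ccc(Cl)cc2)c1C(=O)NC1CCCC1` gives 21200 nM in this assay, and the single measured step, a 1.5-fold higher number from compound 1 to compound 2 (0.17 log units; within the scatter), swapped the group on the carbonyl carbon. Compound 3 `Nc1sc(-c2ccc(Cl)cc2)c(-c2ccc(Cl)cc2)c1C(=O)N1CCNCC1` differs from compound 1 by piperazin-1-yl in place of piperidin-1-yl on a carbonyl carbon. Because a 1.5-fold higher number from compound 1 to compound 2 (0.17 log units; within the scatter) remained within the scatter, the step of a 1.2-fold higher number from compound 1 to compound 3 (0.08 log units; within the scatter) is expected to remain within the scatter too. Compound 3 is therefore estimated at 17000 nM, within 6000 nM to 45000 nM.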

Compound 3, half-maximal inhibitory concentration: 2710 nM
Estimate against measurement, compound 3: 6.3-fold (0.80 log units) above, outside the stated range (below it).
By their numbers in this assay, from the lowest: compound 3; then compounds 1 and 2 (each within the scatter of the next).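

Placing piperazin-1-yl on the carbonyl carbon gives a 5.3-fold lower number from compound 1 to compound 3 (0.72 log units; beyond the scatter) and a 7.8-fold lower number from compound 2 to compound 3 (0.89 log units; beyond the scatter) in this assay so this position can respond clearly to the choice of group. Against piperidin-1-yl the ring stays six-membered, and one ring carbon is exchanged for a nitrogen, so a small edit here is enough to shift the number beyond the scatter. No supporting measurement explains this change.

On these data alone, whether the second ring nitrogen itself matters remains open. Morpholin-4-yl, with oxygen at that ring place, and 4-methylpiperazin-1-yl would be the informative comparisons.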